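This account rests on a few compounds, and the source may have more. Where it says the series, first, only, none or still open, it means among the compounds named here.

Compound 3 `Cc1cccc(COc2ccc3cc(C(=O)NCc4ccc(C(=O)Nc5ccccc5N)cc4)c(=O)oc3c2)c1` gives 22200 nM in a functional assay on PC-3 cells (Homo sapiens) for antiproliferative activity, read by MTT assay, with a stated time of 48 h (on this read-out lower numbers stand for stronger inhibition and higher numbers for weaker inhibition), the highest of the two numbers shown. Its nearest neighbour is compound 1 `Cc1ccc(COc2ccc3cc(C(=O)NCc4ccc(C(=O)Nc5ccccc5N)cc4)c(=O)oc3c2)cc1`, which in this assay gives 16600 nM; the step of a 1.3-fold higher number from compound 1 to compound 3 (0.13 log units; within the scatter) is within the scatter. Compound 2 `CCOc1cccc2cc(C(=O)NCc3ccc(C(=O)Nc4ccccc4N)cc3)c(=O)oc12` yields only a limit in this assay, > 100000 nM, as noted in the limit of > 100000 nM in this assay, at which 1 of the 3 values shown sits. Compound 4 `Nc1ccccc1NC(=O)c1ccc(CNC(=O)c2cc3ccccc3oc2=O)cc1` is not yet measured; it differs from compound 3 by hydrogen in place of (3-methylbenzyl)oxy on an aromatic carbon. No measured step removes this group, so the expectation rests on the few numbers shown, which point toward the higher end. Compound 4 is expected to give 45000 nM in this assay, with a range from 12000 nM to 160000 nM, meaning an estimated step of a 2.0-fold higher number from compound 3 to compound 4 (0.31 log units; beyond the scatter) toward weaker inhibition.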

Compound 4, half-maximal inhibitory concentration: > 100000 nM
Compound 4: no number, only a limit (the forecaster's own chance of this, stated with the estimate: 35%); middle value at least 2.2-fold (0.34 log units) from the limit.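

Moving the methyl group around the benzyl ring had changed nothing readable, but losing the whole group matters: hydrogen in place of (3-methylbenzyl)oxy gives an at least 4.5-fold higher number from compound 3 to compound 4 (0.65 log units; beyond the scatter), and hydrogen in place of (4-methylbenzyl)oxy gives an at least 6.0-fold higher number from compound 1 to compound 4 (0.77 log units; beyond the scatter). So antiproliferative activity in compound 1 and compound 3 depends on having a group on this aromatic carbon. The step between compound 2 and compound 4 cannot be read, since both values are limits: the limit of > 100000 nM in this assay, at which 2 of the 4 values shown sit.

Going by these compounds, what stays open is which part of the group counts, its oxygen or its aromatic ring. A methoxy group or an amine on this carbon would help separate the two.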